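The compounds below may be only part of what the source reports. "The series", "measured", "known", "first", "only" and "open" are said of these compounds alone.

Among the measured compounds shown here, compound 1 `COc1cc(OC)c(/C=C/S(=O)(=O)Cc2ccc(OC)c(N)c2)c(OC)c1` is the one member of this small set for which an ADME assay on MRC5 cells (Homo sapiens) for cytotoxicity, read by MTT assay, with a stated time of 72 h (a lower number here means a stronger inhibitor of growth, a higher number a weaker inhibitor of growth), returns an actual number: in that assay compound 1 gives 80 nM. Compound 2 `COc1ccc(CS(=O)(=O)CC(=O)Nc2c(C)cc(C)cc2C)cc1N` is a different matter, since in this assay compound 2 reaches only a limit, > 30000 nM. Compound 3 `COc1ccc(CS(=O)(=O)CC(=O)Nc2ccccc2)cc1N` behaves the same way, and in this assay compound 3 is likewise recorded as a limit, > 30000 nM. For the measured compounds named here, the set is therefore shaped by the limit of > 30000 nM in this assay, at which 2 of the 3 values shown sit, and compound 1 stands alone as the sole measured value against which anything new can be placed.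

Compound 4 `COc1ccc(CS(=O)(=O)/C=C/c2c(OC)cccc2OC)cc1N` has not yet been run in this assay. It differs from compound 1 in one place: hydrogen in place of methoxy on an aromatic carbon. Going by the values given here, no pair of measured compounds shows what such a change does here, so the size of the step must be guessed rather than read. Compound 4 is expected to come out somewhat weaker than compound 1, with an expected step of a 5.0-fold higher number from compound 1 to compound 4 (0.70 log units; beyond the scatter). Compound 4 is accordingly estimated at 400 nM in this assay, with a plausible range from 100 nM to 2000 nM.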

Compound 4, concentration for 50% growth inhibition: 17100 nM
The estimate for compound 4 lay 43-fold (1.63 log units) below the measured number, outside the stated range (above it).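

Hydrogen in place of this methoxy, which stands para to a large group and meta to two methoxy groups, brings a 210-fold higher number from compound 1 to compound 4 (2.33 log units; beyond the scatter) in this assay. Among the compounds shown here, this is the first single change that can be read in the set, and it shows that the strong inhibition of growth by compound 1 depends heavily on this one methoxy, which the two methoxy groups left on the ring of compound 4 do not make up for. Compound 4 still returns an actual number, however, so this change alone does not bring it to the limit that marks the rest of the set: the limit of > 30000 nM in this assay, at which 2 of the 4 values shown sit.

From the compounds shown here alone, whether a hydroxyl, a methyl or a fluorine on this aromatic carbon would keep the inhibition seen with compound 1 or lose it as hydrogen does remains open, as does whether either of the other two methoxy groups counts for as much. The steps to compound 2 and compound 3 cannot be read, as their entries are limits rather than numbers.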